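The source may hold more compounds than are shown below. What is called first, only, known or untested is meant among the compounds shown, and "the series" means these compounds.

Working notes on the series. In a functional assay on HepG2 cells (Homo sapiens) for cytotoxicity, read by MTT assay, with a stated time of 72 h (on this read-out higher numbers stand for weaker inhibition and lower numbers for stronger inhibition), the three measured compounds spread widely. Compound 1 `O=C(Nc1ccc(Oc2ccnc3[nH]ccc23)cc1)c1nn(-c2ccc(Br)cc2)ccc1=O` gives 4280 nM; compound 2 `Cc1cc(=O)n(-c2ccc(Br)cc2F)nc1C(=O)Nc1ccc(Oc2ncnc3[nH]ccc23)cc1` gives 3660 nM; compound 3 `Cc1cc(=O)n(-c2ccc(Br)cc2F)nc1C(=O)Nc1ccc(Oc2ncnc3c2ccn3C)cc1` gives 33600 nM. Compound 3 therefore stands with the highest number of the three, with compound 1 nearest and compound 2 furthest. Within the data shown here, the one step of a single change that has been measured is a 9.2-fold higher number from compound 2 to compound 3 (0.96 log units; beyond the scatter), a methyl in place of hydrogen on an aromatic nitrogen.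

Compound 4 `Cc1cc(=O)n(-c2ccccc2Cl)nc1C(=O)Nc1ccc(Oc2ncnc3c2ccn3C)cc1` keeps the methylated core of compound 3 and differs only in 2-chlorophenyl in place of 4-bromo-2-fluorophenyl on an aromatic nitrogen. Among the measured compounds shown here, no measured pair differs at this aryl group on the ring nitrogen, so the change from compound 3 to compound 4 is not covered by any step seen so far; the step from compound 2 to compound 3 sits elsewhere and does not bear on it. With nothing to point in either direction, the expectation for compound 4 in this assay is a step no larger than the scatter, that is a 1.1-fold lower number from compound 3 to compound 4 (0.05 log units; within the scatter). Compound 4 is thus estimated at 30000 nM, with a range from 9000 nM to 100000 nM.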

Compound 4, half-maximal inhibitory concentration: 11200 nM
For compound 4 the middle estimate is 2.7-fold (0.43 log units) above the measured one, within the range that was stated.
By their numbers in this assay, from the lowest: compounds 2 and 1 (each within the scatter of the next); then compound 4; then compound 3.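

In this assay, the aryl group on the aromatic nitrogen is now shown to matter: with the methylated core held constant, 2-chlorophenyl in place of 4-bromo-2-fluorophenyl gives a 3.0-fold lower number from compound 3 to compound 4 (0.48 log units; beyond the scatter). Among these compounds, this is the first measured step at this position, and it runs in the opposite direction to the only earlier single change, on the core nitrogen, which gave a 9.2-fold higher number from compound 2 to compound 3 (0.96 log units; beyond the scatter). Nothing available explains why the number changes at this position.

Among the compounds shown here, the single step changes three things at once, the loss of the bromine, the loss of the fluorine and the arrival of the chlorine, so their separate shares remain unresolved, as does whether the same exchange would give a similar step on the core of compound 2, which keeps the hydrogen on the aromatic nitrogen. Going by these compounds, how an amine or a carboxylic acid on this phenyl ring would read in this assay also remains open.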